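Cyclohexyl for isopropyl on the ring amide nitrogen

A few compounds are considered here, and "the series" means these few. Any claim that something is new, unique, unknown or untested is made for them only; others in the source may bear on it.

In a functional assay on A549 cells (Homo sapiens) for antiproliferative activity, read by MTT assay, with a stated time of 72 h (a lower number here means a stronger inhibitor, a higher number a weaker inhibitor), compound 3 `CC(C)N1C(=O)COc2ccc(-c3cccc(NS(=O)(=O)c4ccc(F)cc4)c3)cc21` gives 29400 nM and compound 1 `COc1cccc(N2C(=O)COc3ccc(-c4cnc(Cl)c(NS(=O)(=O)c5ccc(F)cc5)c4)cc32)c1` gives 32700 nM within the scatter of each other. Compound 2 `COc1ccc(N2C(=O)COc3ccc(-c4ccc(O)cc4)cc32)cc1` is reported only as a limit of > 40000 nM in this series. The next change leads to compound 4 `O=C1COc2ccc(-c3cccc(NS(=O)(=O)c4ccc(F)cc4)c3)cc2N1C1CCCCC1` and is cyclohexyl in place of isopropyl on an amide-type nitrogen in a ring with cyclohexyl in place of isopropyl on an amide-type nitrogen in a ring. Going by the values given here, no measured pair isolates this change, so the expectation in this assay rests on compound 3 at 29400 nM as its anchor. The estimated step of a 1.0-fold higher number from compound 3 to compound 4 (0.01 log units; within the scatter) stays within the scatter. For compound 4 the estimated value is 30000 nM with an expected range of 13000 nM to 60000 nM in this assay.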

Compound 4, half-maximal inhibitory concentration: 14500 nM
The estimate for compound 4 lay 2.1-fold (0.32 log units) above the measured number; low and high end bracket the measured number.
By their numbers in this assay, from the lowest: compound 4; then compounds 3 and 1 (each within the scatter of the next). At a limit, above all of these: compound 2.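

Cyclohexyl in place of isopropyl on the ring amide nitrogen in this assay gives a 2.0-fold lower number from compound 3 to compound 4 (0.31 log units; beyond the scatter) and is the only single-place step shown. This position therefore accepts a six-membered carbon ring and responds to the change, although the gain is modest. Nothing among the data shown accounts for the step.

On these data alone, whether ring size or carbon count drives the step remains open. Also open, as far as these compounds go, is how this nitrogen would respond to a longer alkyl chain, an amine or a carboxylic acid.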